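A few compounds are considered here, and "the series" means these few. Any claim that something is new, unique, unknown or untested is made for them only; others in the source may bear on it.

Working notes on an ADME assay on THP-1 cells (Homo sapiens) for cytotoxicity, read by flow cytometry and propidium iodide staining, with a stated time of 72 h; a higher number here means a weaker inhibitor, a lower number a stronger inhibitor. Compound 3 `Cc1nc(CS(=O)(=O)c2ccc(F)cc2)c([N+](=O)[O-])n1C` stands at > 797000 nM, which is only a limit. Compound 1 `Cn1cnc(CS(=O)(=O)c2ccc(F)cc2)c1[N+](=O)[O-]` gives > 835000 nM, also a limit. Compound 2 `Cc1nc(CS(=O)(=O)c2ccc(Br)cc2)c([N+](=O)[O-])n1C` gives a true number, 326000 nM. Compound 4 `Cc1nc(CS(=O)(=O)c2ccc(F)cc2)c([N+](=O)[O-])n1CC(C)O` differs from compound 3 by 1-hydroxyethyl in place of hydrogen on a saturated chain carbon bound to an aromatic nitrogen. The methyl in place of hydrogen on an aromatic carbon gives a step that the two limits leave unreadable from compound 1 to compound 3, so it offers no size to work from. The fluoro in place of bromo on an aromatic carbon gives an at least 2.4-fold higher number from compound 2 to compound 3 (0.38 log units; beyond the scatter), but compound 4 keeps the fluoro. Neither step lies on the saturated chain carbon, so no step beyond the scatter is expected, and a further limit is likely. The expected change is an at least 1.1-fold lower number from compound 3 to compound 4 (0.05 log units; that floor lies within the scatter). The estimate for compound 4 is 700000 nM, with an expected range of 300000 nM to 1000000 nM.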

Compound 4, half-maximal inhibitory concentration: > 699000 nM
Compound 4: a limit, no number; the forecaster's own chance of this, stated with the estimate: 75%; the middle value does not contradict the limit.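

In this assay, compound 3 and compound 4 both stand only as limits, and the step between them cannot be read. The compounds shown leave open whether 1-hydroxyethyl in place of hydrogen at that place changes the reading at all.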